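Dropping the chloro from the acylhydrazone's aryl ring

The compounds below may be only part of what the source reports. "The series", "measured", "known", "first", "only" and "open" are said of these compounds alone.

Two compounds carry the same dimethoxystyryl unit but differ in their linker. Compound 1, `COc1ccc(OC)c(/C=C/c2nnc(Nc3ccc(Cl)cc3)o2)c1`, places an oxadiazole between the alkene and a chloroanilino group; in a functional assay on HOP-62 cells (Homo sapiens) for antiproliferative activity, read by sulforhodamine B assay, with a stated time of 48 h (on this read-out higher numbers stand for weaker inhibition of growth and lower numbers for stronger inhibition of growth), compound 1 gives 2710 nM. Compound 2, `COc1ccc(OC)c(/C=C/C(=O)N/N=C/c2ccc(Cl)cc2)c1`, instead carries an acylhydrazone ending in a chlorophenyl ring, and in this assay compound 2 gives 162 nM, the lower of the two numbers, with a gap to compound 1 that lies well beyond the usual scatter. Compound 3, `COc1ccc(OC)c(/C=C/C(=O)N/N=C/c2ccccc2)c1`, keeps the acylhydrazone of compound 2 and changes only (hydrogen in place of chloro on an aromatic carbon), hydrogen in place of chloro on an aromatic carbon, para to a large group. Among the measured compounds shown here, no measured pair shows this change, so the expectation rests on compound 2 alone. The step from compound 2 to compound 3 is expected to be a small loss of growth inhibition in this assay, close to the edge of the scatter, a 2.0-fold higher number from compound 2 to compound 3 (0.30 log units; within the scatter). Compound 3 is therefore estimated at 320 nM, within a range from 110 nM to 950 nM.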

Compound 3, concentration for 50% growth inhibition: 4950 nM
For compound 3 the middle estimate is 15-fold (1.19 log units) below the measured one; measured number outside the range, above it.
By their numbers in this assay, from the lowest: compound 2; then compounds 1 and 3 (each within the scatter of the next).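

In this assay, among the compounds shown here, the single change from 4-chlorophenyl to phenyl, hydrogen in place of chloro on an aromatic carbon para to a large group, gives a 31-fold higher number from compound 2 to compound 3 (1.49 log units; beyond the scatter) and so is far from a minor edit. For the compounds shown here, for this acylhydrazone pair, the result shows that the chloro at this position matters greatly to growth inhibition, which the earlier compounds could not show since they differ in their linkers. No measurement at hand explains why the loss of this one atom counts for so much.

The compounds shown leave open whether another group at this position, such as fluoro, methoxy or an amine, would keep the growth inhibition of compound 2. They also leave open whether the same change would have a similar effect on compound 1, which carries its chloro on a different linker.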